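This account rests on a few compounds, and the source may have more. Where it says the series, first, only, none or still open, it means among the compounds named here.

In a functional assay on PC-3 cells (Homo sapiens) for antiproliferative activity, read by sulforhodamine B assay, with a stated time of 48 h (on this read-out lower numbers stand for stronger inhibition of growth and higher numbers for weaker inhibition of growth), compound 2 `CN(C)Cc1cn(S(=O)(=O)c2cccc(/C=C/C(=O)NO)c2)c2ccccc12` gives 1030 nM. Compound 1 `Cc1c(CN(C)C)c2ccccc2n1S(=O)(=O)c1cccc(/C=C/C(=O)NO)c1` gives 1690 nM, which is within the usual scatter of compound 2. Compound 3 `CN(C)Cc1cn(Cc2ccc(/C=C/C(=O)NO)cc2)c2ccccc12` gives 2550 nM, a number higher than that of compound 2 by more than the scatter.

The next structure, compound 4 `CN(C)C(=O)c1cn(S(=O)(=O)c2cccc(/C=C/C(=O)NO)c2)c2ccccc12`, changes one group of compound 2: dimethylcarbamoyl in place of (dimethylamino)methyl on an aromatic carbon.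

Only one measured step links two of these compounds in a single place. That step, hydrogen in place of methyl on an aromatic carbon, is a 1.6-fold lower number from compound 1 to compound 2 (0.22 log units; within the scatter), which stays within the scatter. It leaves the (dimethylamino)methyl group untouched, so it gives only a rough sense of how small a single change can be. Among the compounds with values here, no measured compound shows what replacing this group does, so the direction remains open. No shift beyond the scatter is expected, with a slight lean towards a higher number.

The expected change is a 1.4-fold higher number from compound 2 to compound 4 (0.13 log units; within the scatter). Compound 4 is estimated at 1400 nM, with an expected range from 500 nM to 4000 nM.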

Compound 4, concentration for 50% growth inhibition: > 5000 nM
Compound 4: a limit, no number; the forecaster's own chance of this, stated with the estimate: 5%; middle value at least 3.5-fold (0.55 log units) away from the limit.
By their numbers in this assay, from the lowest: compounds 2, 1 and 3 (each within the scatter of the next, the first and the last beyond it). At a limit, above all of these: compound 4.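

In this assay, compound 4 is recorded only as a limit, not as a number: the limit of > 5000 nM in this assay, at which 1 of the 4 values shown sits. The step can still be read: dimethylcarbamoyl in place of (dimethylamino)methyl gives an at least 4.8-fold higher number from compound 2 to compound 4 (0.68 log units; beyond the scatter), so this aromatic carbon of the five-membered ring does not accept every group of similar size, although the counts of hydrogen-bond donors and acceptors are the same for both groups. The earlier step, a 1.6-fold lower number from compound 1 to compound 2 (0.22 log units; within the scatter), left the (dimethylamino)methyl group untouched and could not show this.

On these data alone, it remains open whether other groups on this carbon, such as aminomethyl with a free amine, a longer chain ending in dimethylamino, or a carboxylic acid, would stay close to compound 2 or move towards compound 4. Also open, as far as these compounds go, is whether the same change would act alike on compound 3, which carries the same (dimethylamino)methyl group.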